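Swapping phenyl for (1,3-oxazol-5-yl)carbonyl in compound 1

The source may report more compounds than this note shows. Statements on the series, on what has been measured and on what is new or still open speak of the compounds shown alone.

For the measured compounds named here, in a physicochemical assay for lipophilicity, read by HPLC, measured as chromatographic lipophilicity, at pH 7.4 (a lower number here means a more polar compound, a higher number a more lipophilic compound), compound 1 `O=C(C1CCN(c2ccccc2)CC1)N1N=CC[C@H]1c1ccccc1` gives 6.3, the highest of the three numbers so far. Compound 3 `CC(C)(C)C(=O)N1CCSC1c1ccccc1` comes nearest at 5.6, though still lower beyond the scatter, and compound 2 `CC(=O)N1CCC(C(=O)N2N=CCC2c2ccccc2)CC1` lies furthest away at 2.5. Compound 4 `O=C(c1cnco1)N1CCC(C(=O)N2N=CC[C@H]2c2ccccc2)CC1` has not yet been measured. It carries (1,3-oxazol-5-yl)carbonyl in place of phenyl on an amine nitrogen in a ring. Going by the values given here, no measured pair shows this change directly. With compound 2 at 2.5 as the guide, a large downward step beyond the scatter is expected in this assay. The expected step is a number 3.00 log units lower from compound 1 to compound 4 (beyond the scatter). The estimate for compound 4 is 3.3, within an expected range of 2.6 to 4.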

Compound 4, distribution coefficient: 2.7
Compound 4: the middle estimate sits 0.60 log units above what was measured, and the stated range covers the measured number.
By their numbers in this assay, from the lowest: compounds 2 and 4 (each within the scatter of the next); then compound 3; then compound 1.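

In this assay, putting (1,3-oxazol-5-yl)carbonyl in place of phenyl on the amine nitrogen in the ring gives a number 3.60 log units lower from compound 1 to compound 4 (beyond the scatter). For the compounds shown here, this is the first step measured at this position, and it shows that the number moves strongly with the group carried there. Nothing available accounts for the size of this step. On these data alone, how much of it belongs to the carbonyl and how much to the five-membered aromatic ring stays open. A benzoyl group on the same nitrogen would separate the two.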